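From compound 2 to compound 3: a dichlorophenyl swap

The compounds below may be only part of what the source reports. "The series", "measured", "known", "first", "only" and "open" are said of these compounds alone.

In an ADME assay on NHDF cells (Homo sapiens) for cytotoxicity, read by MTT assay, with a stated time of 72 h (a lower number here means a stronger inhibitor, a higher number a weaker inhibitor), compound 1 `COc1ccc(/C=C2\CCC/C(=C\c3cccc(OC)c3OC)C2=O)cc1OC` gives 14900 nM and compound 2 `COc1ccccc1/C=C1\CCC/C(=C\c2ccc(OC)c(OC)c2)C1=O` gives 18100 nM so the two stand within the scatter of each other. Compound 3 `COc1ccc(/C=C2\CCC/C(=C\c3ccc(Cl)c(Cl)c3)C2=O)cc1OC` carries 3,4-dichlorophenyl in place of 2-methoxyphenyl on a double-bonded chain carbon bound to a double-bonded ring carbon with 3,4-dichlorophenyl in place of 2-methoxyphenyl on a double-bonded chain carbon bound to a double-bonded ring carbon. Going by the values given here, the only measured guide is a 1.2-fold higher number from compound 1 to compound 2 (0.08 log units; within the scatter) which involves no chlorine, so no shift beyond the scatter is expected. The estimated move is a 1.5-fold lower number from compound 2 to compound 3 (0.18 log units; within the scatter) in this assay with low confidence. Compound 3 is estimated at 12000 nM with an expected range from 5000 nM to 30000 nM in this series.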

Compound 3, half-maximal inhibitory concentration: 10100 nM
For compound 3 the middle estimate is 1.2-fold (0.07 log units) above the measured one; measured number inside the range.
By their numbers in this assay, from the lowest: compounds 3, 1 and 2 (each within the scatter of the next).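

On a double-bonded chain carbon bound to a double-bonded ring carbon, 3,4-dichlorophenyl in place of 2-methoxyphenyl gives a 1.8-fold lower number from compound 2 to compound 3 (0.25 log units; within the scatter) in this assay. This is the first chlorine-bearing group shown at this place, and it tolerates the loss of the methoxy group and the entry of chlorine without a step beyond the scatter. No measurement here bears on the reason for this reading.

All steps shown remain within the scatter, so no group has yet been seen to move the number at this place. As far as these compounds go, whether an amine, a carboxylic acid or a longer chain here would do so stays open.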